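The source may report more compounds than this note shows. Statements on the series, on what has been measured and on what is new or still open speak of the compounds shown alone.

Compound 1 `c1ccc(NN=C(c2nc3ccccc3[nH]2)c2nc3ccccc3[nH]2)cc1` and compound 2 `Cc1ccc(NN=C(c2nc3ccccc3[nH]2)c2nc3ccccc3[nH]2)cc1` share one core and differ only in a group on an aromatic carbon. In a functional assay on PC-3 cells (Homo sapiens) for cytotoxicity, read by MTT assay, with a stated time of 72 h (on this read-out lower numbers stand for stronger inhibition and higher numbers for weaker inhibition), compound 1 gives 248000 nM, and compound 2 gives 250000 nM. The step of a 1.0-fold higher number from compound 1 to compound 2 (0.00 log units; within the scatter) thus changed nothing the measurement can resolve. Among the compounds with values here, compound 2 stands at the higher of the two numbers, but its only neighbour, compound 1, lies within the scatter of it, so no order can be read between them. Compound 3 `COc1ccc(NN=C(c2nc3ccccc3[nH]2)c2nc3ccccc3[nH]2)cc1`, not yet measured, differs from compound 2 by methoxy in place of methyl on an aromatic carbon. No measured step exchanges a methyl for a methoxy, so the only guide is the single step shown, which stayed within the scatter. On that basis compound 3 is expected to show no step beyond the scatter in this assay, the expected step being no change at the digits printed from compound 2 to compound 3 (within the scatter). The estimate for compound 3 is 250000 nM, with a range from 120000 nM to 500000 nM.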

Compound 3, half-maximal inhibitory concentration: 250000 nM
Estimate against measurement, compound 3: no gap at the digits printed; low and high end bracket the measured number.
By their numbers in this assay, from the lowest: compounds 1, 2 and 3 (each within the scatter of the next).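

In this assay, methoxy in place of methyl on the aromatic carbon para to a large group gave no change at the digits printed from compound 2 to compound 3 (within the scatter), and methoxy in place of hydrogen at the same carbon gave a 1.0-fold higher number from compound 1 to compound 3 (0.00 log units; within the scatter). The earlier pair had covered only hydrogen and methyl; this result extends the comparison to an oxygen-linked group that brings one hydrogen-bond acceptor, and the three compounds still cannot be told apart at this position. No supporting information bears on why the numbers stay level.

As far as these compounds go, whether an amine or a carboxylic acid at this carbon would move the number beyond the scatter remains open. So does whether a change elsewhere on the shared core would have any more effect than these three groups.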